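Nitro on the fused benzo ring: cytotoxicity working notes

The source may hold more compounds than are shown below. What is called first, only, known or untested is meant among the compounds shown, and "the series" means these compounds.

Measured in a functional assay on HepG2 cells (Homo sapiens) for cytotoxicity, read by MTT assay; a higher number here means a weaker inhibitor, a lower number a stronger inhibitor:
compound 1 `CC1=NN(Cc2nc3ccccc3[nH]2)C(=O)C1` gives 54000 nM
compound 2 `O=[N+]([O-])c1ccc2[nH]c(CNc3nc4ccc(F)cc4s3)nc2c1` gives 263000 nM
compound 3 `Fc1ccc2nc(NCc3nc4ccccc4[nH]3)sc2c1` gives 233000 nM

Compound 1 holds the lowest of the three numbers in this assay; its steps to compound 3 and to compound 2 are both beyond the scatter. Compounds 2 and 3 lie within the scatter of each other, so no order is read between them.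

One structural change is seen twice in the set. From compound 3 to compound 2 it is nitro in place of hydrogen on an aromatic carbon, and the measured step is a 1.1-fold higher number from compound 3 to compound 2 (0.05 log units; within the scatter). The same change, (nitro in place of hydrogen on an aromatic carbon), turns compound 1 into compound 4 `CC1=NN(Cc2nc3cc([N+](=O)[O-])ccc3[nH]2)C(=O)C1`, which is not yet measured. The place lines of the two changes agree word for word, so this is taken as the same change on two cores. The difference between the core of compound 1 and the core of compound 3 is not broken down here.

For compound 4 the step from compound 1 in this assay is expected to be about a 1.1-fold higher number from compound 1 to compound 4 (0.06 log units; within the scatter), set beside the measured step from compound 3 to compound 2; the expectation rests on that single precedent, because a 1.1-fold higher number from compound 3 to compound 2 (0.05 log units; within the scatter) stayed within the scatter. With one example only, the range is kept wide. Compound 4 is estimated at 62000 nM, between 25000 nM and 160000 nM.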

Compound 4, half-maximal inhibitory concentration: 265000 nM
Compound 4: middle estimate off by 4.3-fold (0.63 log units), on the low side, outside the stated range (above it).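

In this assay, nitro in place of hydrogen on an aromatic carbon gives a 4.9-fold higher number from compound 1 to compound 4 (0.69 log units; beyond the scatter), so on the core of compound 1 the change moves the number by more than the scatter. Set beside the earlier step, the change does not carry over at one size between the two cores: the same change on two cores in this assay, a 1.1-fold higher number (0.05 log units; within the scatter) from compound 3 to compound 2 and a 4.9-fold higher number (0.69 log units; beyond the scatter) from compound 1 to compound 4, 4.3-fold (0.64 log units) apart, beyond the scatter of two such steps

Among the compounds shown here, this shows that, in this series, a step read on one core is a poor guide to the same change on the other, and that the single precedent could not be transferred directly; it does not show which structural part of the two cores sets the difference, why the steps differ, or how the change would behave on any further core, as each core supplies only one pair.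

Across these pairs, only hydrogen and nitro are seen at this place on the fused ring, so it remains open whether an amine, a methoxy group or a carboxylic acid there would follow the larger step, the smaller one or neither. The parts in which the core of compound 1 and the core of compound 3 differ also remain to be separated, one change at a time.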